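Pyridin-4-yl hydrazone explored on a quinoline urea scaffold

This account rests on a few compounds, and the source may have more. Where it says the series, first, only, none or still open, it means among the compounds named here.

Compound 1, `COc1cc2c(Oc3ccc(NC(=O)N/N=C/c4ccc(C(F)(F)F)cc4)cc3F)ccnc2cc1OCCCN1CCCC1`, serves as the reference point in a functional assay on A549 cells (Homo sapiens) for cytotoxicity, read by MTT assay, with a stated time of 72 h (a lower number here means a stronger inhibitor, a higher number a weaker inhibitor), where compound 1 gives 790 nM. Compound 2, `COc1cc2c(Oc3ccc(NC(=O)N/N=C/c4ccc(Cl)cc4Cl)cc3F)ccnc2cc1OCCCN1CCCCC1`, carries the same core with a different six-membered ring at the hydrazone carbon, yet in this assay compound 2 is recorded as "not determined" (no result reported), so no single number describes where compound 2 stands. Compound 3, `COc1cc2c(Oc3ccc(NC(=O)N/N=C/c4ccncc4)cc3F)ccnc2cc1OCCCN1CCCCC1`, is the unmeasured analogue, and the change from compound 2 to compound 3 is pyridin-4-yl in place of 2,4-dichlorophenyl on a carbon with a double bond to nitrogen. For the measured compounds named here, with no measured pair showing this change, the size of the step in this assay is uncertain; a modest move toward weaker inhibition, of a size that may reach beyond the usual scatter, appears plausible, though a step within the scatter cannot be ruled out. Taking compound 1 with 790 nM as the only anchor, compound 3 is expected to give about 1500 nM in this assay, within a range from 400 nM to 6000 nM.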

Compound 3, half-maximal inhibitory concentration: 840 nM
Compound 3: the middle estimate sits 1.8-fold (0.25 log units) above what was measured; the range from low to high includes it.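

For the compounds shown here, compound 2 has no single number in this assay, so no step from it to compound 3 can be read. The compounds shown leave open what pyridin-4-yl in place of 2,4-dichlorophenyl does in this assay. No available evidence bears on this result.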